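The source may report more compounds than this note shows. Statements on the series, on what has been measured and on what is new or still open speak of the compounds shown alone.

Compound 2 `CC1CCCCN1C(=S)SCc1ccc(C(=O)Nc2ccccc2N)cc1` stands highest of the three numbers in a functional assay on MGC-803 cells (Homo sapiens) for antiproliferative activity, read by CCK-8 assay, with a stated time of 72 h, tested at 8 uM; on this read-out higher numbers stand for a stronger effect at the one concentration tested and lower numbers for a weaker effect: compound 2 reaches 86.9%. Compound 3 `N#Cc1ccc(N2CCN(C(=S)SCc3ccc(C(=O)Nc4ccccc4N)cc3)CC2)cc1` comes nearest, and in this assay compound 3 gives 37.6%; compound 1 `COc1ccc(N2CCN(C(=S)SCc3ccc(C(=O)Nc4ccccc4N)cc3)CC2)cc1` lies furthest, and in this assay compound 1 gives 22.9%. Among the compounds with values here, the one measured step, a number 14.7 percentage points higher from compound 1 to compound 3 (beyond the scatter), concerns a different position and does not bear directly on the change considered here. Compound 4 `CN(Cc1ccncc1)C(=S)SCc1ccc(C(=O)Nc2ccccc2N)cc1` differs from compound 2 by methyl((pyridin-4-yl)methyl)amino in place of 2-methylpiperidin-1-yl on a thiocarbonyl carbon. Within the data shown here, no measured step covers this replacement; the values of compound 1 and compound 3 only show that the group on the thiocarbonyl carbon can move the number a long way. A downward step is therefore expected, a number 31.9 percentage points lower from compound 2 to compound 4 (beyond the scatter). The estimate for compound 4 is 55%, within 25% to 85%.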

Compound 4, a percentage reported as inhibition, at one concentration (the size of the read-out at that concentration, not a potency): 83.2%
Beside the measured number, compound 4's estimate is 28.2 percentage points below it; measured number inside the range.
By their numbers in this assay, from the lowest: compound 1; then compound 3; then compounds 4 and 2 (each within the scatter of the next).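

In this assay, within the data shown here, methyl((pyridin-4-yl)methyl)amino in place of 2-methylpiperidin-1-yl on a thiocarbonyl carbon gives a number 3.7 percentage points lower from compound 2 to compound 4 (within the scatter), a replacement the earlier compounds did not cover. On this read-out, the non-aromatic ring of the group that leaves is therefore not needed at this position, since a group with a six-membered aromatic ring serves equally well. No available evidence accounts for this result. Open, on these data alone, is whether a phenyl ring could stand in for the pyridine of compound 4, and whether a morpholine would hold the number.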